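The source may report more compounds than this note shows. Statements on the series, on what has been measured and on what is new or still open speak of the compounds shown alone.

Measured in a functional assay on MGC-803 cells (Homo sapiens) for inhibition, read by MTT assay, with a stated time of 72 h; on this read-out higher numbers stand for weaker inhibition and lower numbers for stronger inhibition:

compound 1 `O=C(CSc1nc(Nc2ccccc2)c2ccccc2n1)Nc1ccc(Cl)cc1`: 40400 nM
compound 2 `O=C(CSc1nc(Nc2ccccc2)c2ccccc2n1)Nc1ccc(Br)cc1`: 19300 nM
compound 3 `C=CC(=O)Nc1cccc(NC(=O)CSc2nc(Nc3cccc(Cl)c3)c3ccccc3n2)c1`: 7830 nM

Compound 1 and compound 2 share one core and differ in a single spot: bromo in place of chloro on an aromatic carbon. That change gave a 2.1-fold lower number from compound 1 to compound 2 (0.32 log units; beyond the scatter). Compound 3 carries a different core; how its core differs from that of compound 1 is not broken down here, but compound 3 gives the lowest number of the three, with the smallest gap to compound 2 and the largest to compound 1.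

Compound 4 `C=CC(=O)Nc1cccc(NC(=O)CSc2nc(Nc3cccc(Br)c3)c3ccccc3n2)c1` has not yet been measured in this assay. It differs from compound 3 by bromo in place of chloro on an aromatic carbon. Among the compounds with values here, this is the same kind of change as the one from compound 1 to compound 2, though not the same: there the bromo sits para to a large group, here it sits meta to a large group. Within the data shown here, since only one earlier example exists, the expectation is cautious. For compound 4 a step of about a 1.7-fold lower number from compound 3 to compound 4 (0.24 log units; within the scatter) is expected, resting on the earlier change because a 2.1-fold lower number from compound 1 to compound 2 (0.32 log units; beyond the scatter). Compound 4 is therefore estimated at 4500 nM, between 2000 nM and 10000 nM.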

Compound 4, half-maximal inhibitory concentration: 11900 nM
Compound 4: middle estimate off by 2.6-fold (0.42 log units), on the low side; the whole stated range lies below it.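

Putting bromo in place of chloro on the core of compound 3 gave a 1.5-fold higher number from compound 3 to compound 4 (0.18 log units; within the scatter), so this assay does not tell these two compounds apart. The lower number that the same swap gave on the core of compound 1 was therefore not repeated on the core of compound 3, and the two results differ: the same change on two cores in this assay, a 2.1-fold lower number (0.32 log units; beyond the scatter) from compound 1 to compound 2 and a 1.5-fold higher number (0.18 log units; within the scatter) from compound 3 to compound 4, 3.2-fold (0.50 log units) apart, beyond the scatter of two such steps. Within the data shown here, this shows that the effect of the swap cannot simply be assumed to carry from one core to another, but it does not show what lies behind the difference, as there is only one pair on each core, and the pairs differ both in their cores and in where the halogen sits.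

On these data alone, it remains open whether fluoro, iodo or methyl at this spot would stand apart from chloro and bromo on either core. As far as these compounds go, it also remains open whether the swap would behave the same way if a saturated propanamide replaced the acrylamide of compound 3 and compound 4.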